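This account rests on a few compounds, and the source may have more. Where it says the series, first, only, none or still open, it means among the compounds named here.

Working notes on the series. The shared core is seen in compound 2 `CC(O)c1cccc(C(=O)N[C@@H](C)Cn2ccc(-c3ccc(C#N)c(Cl)c3)n2)c1`, compound 3 `C[C@@H](Cn1ccc(-c2ccc(C#N)c(Cl)c2)n1)NC(=O)c1cccc(OCC(O)CO)c1`, compound 4 `CC(=O)c1ccc(C(=O)N[C@@H](C)Cn2ccc(-c3ccc(C#N)c(Cl)c3)n2)cc1` and the ring-substituted analogue compound 1 `CC(=O)c1cc(C(=O)N[C@H](C)Cn2ccc(-c3cc(F)c(C#N)c(Cl)c3)n2)n[nH]1`. In an ADME assay on PC-3 cells (Homo sapiens) for cytotoxicity, read by CCK-8 assay, with a stated time of 6 days (a lower number here means a stronger inhibitor, a higher number a weaker inhibitor), compound 1 is recorded as "not determined" (no result reported). In this assay compound 2 reaches only the assay limit, > 30000 nM. Compound 3 in this assay likewise reaches only the assay limit, > 30000 nM. The step that the two limits leave unreadable from compound 2 to compound 3, which puts 2,3-dihydroxypropoxy in place of 1-hydroxyethyl on an aromatic carbon, therefore has no readable size. Compound 2 thus stands at the limit of > 30000 nM in this assay, at which 2 of the 3 values shown sit; nothing in the set places it at a number.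

The change to compound 4 is 4-acetylphenyl in place of 3-(1-hydroxyethyl)phenyl on a carbonyl carbon: the 3-(1-hydroxyethyl)phenyl group leaves and 4-acetylphenyl enters on the carbonyl carbon whose other neighbour is the amide-type nitrogen, with one hydrogen-bond donor fewer and one double bond outside aromatic rings added.

Going by the values given here, only the step from compound 2 to compound 3 bears on this change, and it is unreadable, so no measured step gives a direction. The expectation for this assay rests on compound 2 sitting at the limit of > 30000 nM in this assay, at which 2 of the 3 values shown sit: the step of a number no higher from compound 2 to compound 4 (the limit leaves the size open) is expected to be none beyond the scatter, with a strong chance that only a limit is returned. Compound 4 is expected at 30000 nM, in the range 10000 nM to 90000 nM.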

Compound 4, half-maximal inhibitory concentration: > 30000 nM
Compound 4: a limit, no number; the forecaster's own chance of this, stated with the estimate: 70%; the middle value lies on the limit itself.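

In this assay compound 4 gives > 30000 nM, which is a limit and not a number. With compound 2 and compound 4 both at limits, no new step can be read between them. The compounds shown leave open what size, if any, the change to 4-acetylphenyl has in this assay.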